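Naphthalen-1-yl in place of phenyl on the carbonyl

This account rests on a few compounds, and the source may have more. Where it says the series, first, only, none or still open, it means among the compounds named here.

The shared core is carried by compound 1 `COc1cc(-c2nnc3n2NC(c2ccco2)C(C(=O)c2ccccc2C)S3)cc(OC)c1OC` and compound 2 `COc1cc(-c2nnc3n2NC(c2ccco2)C(C(=O)c2ccccc2)S3)cc(OC)c1OC`. Among the compounds with values here, in a functional assay on MCF7 cells (Homo sapiens) for cytotoxicity, read by MTT assay, with a stated time of 48 h (a lower number here means a stronger inhibitor, a higher number a weaker inhibitor), compound 1 gives 69900 nM and compound 2 gives 39800 nM; the step of a 1.8-fold lower number from compound 1 to compound 2 (0.24 log units; within the scatter) leaves the two within the scatter, so compound 2 stands level with compound 1 on the numbers so far. Compound 3 `COc1cc(-c2nnc3n2NC(c2ccco2)C(C(=O)c2cccc4ccccc24)S3)cc(OC)c1OC` differs from compound 2 by naphthalen-1-yl in place of phenyl on a carbonyl carbon. Within the data shown here, only the step from compound 1 to compound 2 touches this position, and it was small; no measured step adds a fused ring. The expected change is a 1.0-fold higher number from compound 2 to compound 3 (0.00 log units; within the scatter), nothing beyond the scatter. Compound 3 is therefore estimated at 40000 nM in this assay, within 10000 nM to 160000 nM.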

Compound 3, half-maximal inhibitory concentration: > 100000 nM
Compound 3: no number, only a limit; the forecaster's own chance of this, stated with the estimate: 10%; middle value at least 2.5-fold (0.39 log units) away from the limit.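

In this assay compound 3 gives a limit, not a number: the limit of > 100000 nM in this assay, at which 1 of the 3 values shown sits.

Even so, naphthalen-1-yl in place of phenyl on the carbonyl carbon gives an at least 2.5-fold higher number from compound 2 to compound 3 (0.40 log units; beyond the scatter), the first step at this position to pass the scatter. Naphthalen-1-yl in place of 2-methylphenyl gives an at least 1.4-fold higher number from compound 1 to compound 3 (0.15 log units; that floor lies within the scatter), a floor that does not separate the two.

Going by these compounds, the true size of both steps remains open. Also open, on these data alone, is how a carboxylic acid or a dimethylamino group on the phenyl of compound 2 would read in this assay.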